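Trifluoromethoxy on the anilide ring of a dithiol amide

The compounds below may be only part of what the source reports. "The series", "measured", "known", "first", "only" and "open" are said of these compounds alone.

Measured compounds:
compound 1 `O=C(CCCCC(S)CCS)Nc1ccccc1` with 25.4%
compound 2 `O=C(CCCCC(S)CCS)Nc1ccccc1Cl` with 12.1%
compound 3 `O=C(CCCCC(S)CCS)Nc1cccc(C(F)(F)F)c1` with 32.1%

In a functional assay on NCI-H460 cells (Homo sapiens) for inhibition, read by MTT assay, with a stated time of 24 h, tested at 100 ug/mL (a higher number here means more inhibition of growth at the concentration tested, a lower number less inhibition of growth), compound 1 stands second highest of the three numbers, with compound 3 nearest, a number 6.7 percentage points higher from compound 1 to compound 3 (within the scatter), and compound 2 furthest, a number 13.3 percentage points lower from compound 1 to compound 2 (beyond the scatter). Compound 4 `O=C(CCCCC(S)CCS)Nc1ccc(OC(F)(F)F)cc1` differs from compound 1 by one change: trifluoromethoxy in place of hydrogen on an aromatic carbon. Going by the values given here, two measured steps bear on it, both changes on an aromatic carbon of the same ring: the chloro step to compound 2 was a modest drop beyond the scatter, while the trifluoromethyl step to compound 3 stayed within it. A fluorinated group that sits para to a large group is therefore expected to leave this assay near the value of compound 1, with no step beyond the scatter, a number 2.6 percentage points higher from compound 1 to compound 4 (within the scatter). Compound 4 is estimated at 28%, between 12% and 44%.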

Compound 4, percent growth inhibition at one concentration: 65.1%
Compound 4: middle estimate off by 37.1 percentage points, on the low side; measured number above the stated range.
By their numbers in this assay, from the lowest: compound 2; then compounds 1 and 3 (each within the scatter of the next); then compound 4.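

In this assay the trifluoromethoxy change, para to a large group, gives a number 39.7 percentage points higher from compound 1 to compound 4 (beyond the scatter), the only step among these compounds that raises the number beyond the scatter. The chloro step instead gave a number 13.3 percentage points lower from compound 1 to compound 2 (beyond the scatter), and the trifluoromethyl step gave a number 6.7 percentage points higher from compound 1 to compound 3 (within the scatter), so a change on this ring can produce a large gain as well as a loss. No measurement here accounts for that gain. The compounds shown leave open whether methoxy or an amine at this same place would give a similar number.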